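The source may report more compounds than this note shows. Statements on the series, on what has been measured and on what is new or still open speak of the compounds shown alone.

Compound 1 `COc1cccc(CNCCCNc2ccnc3cc(Oc4ccccc4)ccc23)c1O` and compound 2 `COc1ccccc1Oc1ccc2c(NCCCNCc3cccc(OC)c3O)ccnc2c1` share one core and differ only by a methoxy in place of hydrogen on an aromatic carbon. In an ADME assay for permeability, using PAMPA, with a stated time of 30 min, at pH 7.4 (on this read-out higher numbers stand for higher permeability and lower numbers for lower permeability), compound 1 gives 317 10^-6 cm/s, and compound 2 gives 317 10^-6 cm/s; the step of no change at the digits printed from compound 1 to compound 2 (within the scatter) was thus nil within the scatter. Compound 2 therefore stands level with compound 1 at the digits shown, and no other measured compound sits higher or lower than it. Compound 3 `COc1cccc(CNCCCNc2ccnc3cc(-c4cccc5ccccc45)ccc23)c1O` differs from compound 2 by naphthalen-1-yl in place of 2-methoxyphenoxy on an aromatic carbon. Within the data shown here, no measured step covers an exchange of this size; the only step available, no change at the digits printed from compound 1 to compound 2 (within the scatter), shows no change but alters far less of the molecule. With nothing in the data pointing to a direction, no step beyond the scatter is expected, so compound 3 is estimated at 317 10^-6 cm/s, between 160 10^-6 cm/s and 500 10^-6 cm/s, a step of no change at the digits printed from compound 2 to compound 3 (within the scatter).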

Compound 3, apparent permeability: 237 10^-6 cm/s
For compound 3 the middle estimate is 1.3-fold (0.13 log units) above the measured one; measured number inside the range.
By their numbers in this assay, from the lowest: compounds 3, 1 and 2 (each within the scatter of the next).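

In this assay, putting naphthalen-1-yl in place of 2-methoxyphenoxy gives a 1.3-fold lower number from compound 2 to compound 3 (0.13 log units; within the scatter) and putting it in place of phenoxy gives a 1.3-fold lower number from compound 1 to compound 3 (0.13 log units; within the scatter) at the same aromatic carbon. The earlier compounds shown here showed only the small methoxy exchange, whereas here a group with one six-membered aromatic ring and 2 hydrogen-bond acceptors leaves, one with 2 such rings and 0 acceptors enters, and the step still stays within the scatter. No measurement at hand offers an explanation for this result.

The compounds shown leave open whether an amine or a carboxylic acid on this aromatic carbon would also stay within the scatter. They also leave open how a longer chain in the amine-bearing linker would read, as every step shown concerns this one substituent.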